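Bromo for chloro on the shared core

The source may hold more compounds than are shown below. What is called first, only, known or untested is meant among the compounds shown, and "the series" means these compounds.

compound 1 `O=c1[nH]c(=O)n(COCCO)c([Se]c2ccccc2)c1F` measured at 25700 nM
compound 2 `O=c1[nH]c(=O)n(COCCO)c([Se]c2ccccc2)c1Cl` measured at 7500 nM
compound 3 `O=c1[nH]c(=O)n(COCCO)c([Se]c2ccccc2)c1Br` not yet measured

In a toxicity assay on Vero cells (Chlorocebus sabaeus) for cytotoxicity (a lower number here means a stronger inhibitor, a higher number a weaker inhibitor), compound 2 holds the lower of the two measured numbers, at 7500 nM, and so stands ahead of compound 1 on this read-out. The change to compound 3 is bromo in place of chloro on an aromatic carbon. Among the measured compounds shown here, only one measured step bears on it, chloro in place of fluoro on an aromatic carbon, and that step is modest: a 3.4-fold lower number from compound 1 to compound 2 (0.53 log units; beyond the scatter). A single step sets no trend, but a similar or smaller move in the same direction is expected in this assay. The expected step is a 1.6-fold lower number from compound 2 to compound 3 (0.19 log units; within the scatter), and it may not clear the scatter. Compound 3 is estimated at 4800 nM, with an expected range of 1700 nM to 13000 nM.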

Compound 3, half-maximal inhibitory concentration: 8200 nM
Estimate against measurement, compound 3: 1.7-fold (0.23 log units) below, within the range that was stated.
By their numbers in this assay, from the lowest: compounds 2 and 3 (each within the scatter of the next); then compound 1.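

In this assay, replacing chloro with bromo gives a step that stays within the scatter (a 1.1-fold higher number from compound 2 to compound 3 (0.04 log units; within the scatter)), so this position of the shared core does not separate these two halogens, and the move seen on going from fluoro to chloro does not continue on going to bromo. Bromo in place of fluoro gives a step beyond the scatter (a 3.1-fold lower number from compound 1 to compound 3 (0.50 log units; beyond the scatter)), which leaves fluoro apart from chloro and bromo among the three compounds shown. No measurement at hand accounts for this result.

The compounds shown leave open how an iodo, a methyl or an amino group on this aromatic carbon would read in this assay and whether it would side with fluoro or with the other two halogens. They also leave open whether fluoro stays apart from chloro and bromo when a longer chain takes the place of the (2-hydroxyethoxy)methyl group.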